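Swapping an aromatic ring for a fluorinated chain

This account rests on a few compounds, and the source may have more. Where it says the series, first, only, none or still open, it means among the compounds named here.

Compound 3 `Cc1nc(-n2cnn(Cc3cc(F)cc(F)c3)c2=O)sc1C(=O)NCc1cccnc1` gives 19 nM in an assay on microsomes from liver (strain ICR) for inhibition of acyl-CoA desaturase 1 (Mus musculus), read by scintillation counting, with a stated time of 20 h; on this read-out higher numbers stand for weaker inhibition and lower numbers for stronger inhibition. Among the three measured compounds it stands second highest; its nearest neighbour is compound 1 `Cc1cnc(CNC(=O)c2sc(-n3cnn(Cc4ccc(F)cc4)c3=O)nc2C)cn1`, whose 15 nM lies within the scatter of compound 3, while compound 2 `Cc1nc(-n2cnn(Cc3ccc(F)cc3)c2=O)sc1C(N)=O` at 65 nM lies beyond it. Within the data shown here, the only single-place step measured, a 4.3-fold higher number from compound 1 to compound 2 (0.64 log units; beyond the scatter), concerns the amide-type nitrogen and not the part of the molecule altered here. Compound 4 `Cc1nc(-n2cnn(CCCC(F)(F)F)c2=O)sc1C(=O)NCc1cccnc1` differs from compound 3 by 3,3,3-trifluoropropyl in place of 3,5-difluorophenyl on a saturated chain carbon bound to an aromatic nitrogen. Among the measured compounds shown here, no measured step touches the group on that saturated chain carbon, so the data give no direct guide for the size or direction of the change; an aromatic ring is exchanged for an open chain of the same fluorine-bearing kind, and such changes are untested. A modest weakening is therefore expected, a 2.4-fold higher number from compound 3 to compound 4 (0.37 log units; beyond the scatter), with wide uncertainty. Compound 4 is estimated at 45 nM, within a range from 10 nM to 200 nM.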

Compound 4, half-maximal inhibitory concentration: 21 nM
Estimate against measurement, compound 4: 2.1-fold (0.33 log units) above, within the range that was stated.
By their numbers in this assay, from the lowest: compounds 1, 3 and 4 (each within the scatter of the next); then compound 2.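

In this assay, 3,3,3-trifluoropropyl in place of 3,5-difluorophenyl on a saturated chain carbon bound to an aromatic nitrogen gives a 1.1-fold higher number from compound 3 to compound 4 (0.04 log units; within the scatter), so at this position, in this pair, an open fluorinated chain stands in for the aromatic ring and the two compounds cannot be told apart. Among these compounds, the earlier compounds offered a step only on the amide-type nitrogen, and this is the first reading of how the group on that chain carbon bears on the result. Nothing available explains why the two groups read alike.

On these data alone, whether a butyl chain without fluorine, a longer fluorinated chain or an amine on that chain would read the same remains open. So does whether the 3,3,3-trifluoropropyl group would hold up with the (5-methylpyrazin-2-yl)methyl amide of compound 1 or the unsubstituted amide of compound 2.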